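Amide ring swap at the aryl carbonyl of a spiro series

The compounds below may be only part of what the source reports. "The series", "measured", "known", "first", "only" and "open" are said of these compounds alone.

Compound 1 `CC(C)OC(=O)N1CCC2(CC1)CC(CCCOc1ccc(S(C)(=O)=O)c(F)c1)C2`: 18 nM
Compound 2 `CC(C)OC(=O)N1CCC2(CC1)CC(CCCOc1ccc(C(=O)N(C)C3CC3)c(F)c1)C2`: 67 nM

In a functional assay on cells for agonist activity at Glucose-dependent insulinotropic receptor (Homo sapiens), read by HTRF and cAMP accumulation, with a stated time of 30 min (on this read-out higher numbers stand for an effect only at larger amounts of compound and lower numbers for an effect already at smaller amounts), compound 1 gives 18 nM and compound 2 gives 67 nM. Compound 2 therefore stands at the higher of the two numbers, with the step of a 3.7-fold higher number from compound 1 to compound 2 (0.57 log units; beyond the scatter) lying beyond the scatter. Compound 3 `CC(C)OC(=O)N1CCC2(CC1)CC(CCCOc1ccc(C(=O)N3CCCC3)c(F)c1)C2` differs from compound 2 in one place: pyrrolidin-1-yl in place of cyclopropyl(methyl)amino on a carbonyl carbon. Within the data shown here, no measured step in this set touches the amine part of the carbamoyl group; the only step, from compound 1 to compound 2, exchanges a whole sulfonyl for a carbamoyl and does not bear on a swap within the amide. With the same atoms joined differently and no change in donors or acceptors, compound 3 is expected to sit close to compound 2, with a step of a 1.0-fold higher number from compound 2 to compound 3 (0.02 log units; within the scatter) in this assay, within the scatter. Compound 3 is thus estimated at 70 nM, in the range 30 nM to 170 nM.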

Compound 3, half-maximal effective concentration: 29 nM
Compound 3: the middle estimate sits 2.4-fold (0.38 log units) above what was measured; the whole stated range lies above it.
By their numbers in this assay, from the lowest: compounds 1 and 3 (each within the scatter of the next); then compound 2.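

In this assay, the amine part on the carbonyl carbon turns out not to be a neutral place: with the same atoms joined differently, pyrrolidin-1-yl in place of cyclopropyl(methyl)amino gives a 2.3-fold lower number from compound 2 to compound 3 (0.36 log units; beyond the scatter). The exchange of methylsulfonyl for (pyrrolidin-1-yl)carbonyl gives a 1.6-fold higher number from compound 1 to compound 3 (0.21 log units; within the scatter), so a carbonyl amide on this aromatic carbon can stay level with methylsulfonyl, which the cyclopropyl(methyl)carbamoyl group of compound 2 did not do. Nothing measured here accounts for the difference between the two amides.

Still open, as far as these compounds go, is whether the step follows from closing the amine into a ring or from this ring in particular. Azetidin-1-yl, piperidin-1-yl, morpholin-4-yl or dimethylamino on the same carbonyl carbon would help separate the two readings.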